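A few compounds are considered here, and "the series" means these few. Any claim that something is new, unique, unknown or untested is made for them only; others in the source may bear on it.

In a functional assay on MGC-803 cells (Homo sapiens) for antiproliferative activity, read by MTT assay, with a stated time of 72 h (on this read-out higher numbers stand for weaker inhibition and lower numbers for stronger inhibition), compound 1 `CCCSc1nc(N/N=C/c2ccc(C)cc2)c2nnn(Cc3ccccc3)c2n1` reads > 64000 nM, which is a limit of the assay and not a number. Its true position is therefore known from one side only. Two related compounds do return numbers: compound 2 `C#CCSc1nc(N/N=C(\C)c2ccccc2O)c2nnn(Cc3ccccc3)c2n1` gives 3820 nM, and compound 3 `CCCSc1nc(N/N=C(\C)c2ccccc2O)c2nnn(Cc3ccc(O)cc3)c2n1` gives 7680 nM.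

The next compound to be tested, compound 4 `CCCSc1nc(N/N=C/c2cccc(Cl)c2)c2nnn(Cc3ccccc3)c2n1`, keeps the shared core of compound 1 and exchanges a single group, with 3-chlorophenyl in place of 4-methylphenyl on a carbon with a double bond to nitrogen. Within the data shown here, no measured pair in this small set differs in one place only, so the data give no direct size for such a change. Any forecast therefore starts from a limit and stays loose.

In this assay, the expectation is a modest move towards stronger inhibition, and a second reading at the limit would be no surprise. The estimated change, an at least 1.6-fold lower number from compound 1 to compound 4 (0.20 log units; that floor lies within the scatter), is small and uncertain. In this assay, the expected value for compound 4 is 40000 nM, with an estimated range from 14000 nM to 90000 nM.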

Compound 4, half-maximal inhibitory concentration: > 64000 nM
Compound 4 ended at the assay's limit (the forecaster's own chance of this, stated with the estimate: 45%); middle value at least 1.6-fold (0.20 log units) away from the limit.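

No step can be read from compound 1 to compound 4 in this assay because both compounds stop at a limit of the assay rather than giving a number: the limit of > 64000 nM in this assay, at which 2 of the 4 values shown sit.

Going by these compounds, it therefore remains open whether 4-methylphenyl or 3-chlorophenyl gives stronger inhibition, and how much activity, if any, either compound has past that limit.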